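The source may report more compounds than this note shows. Statements on the series, on what has been measured and on what is new or still open speak of the compounds shown alone.

Compound 1 `O=C(/C=C/c1cccc(OCc2ccccc2)c1)c1ccccc1Br`: 2200 nM
Compound 2 `O=C(/C=C/c1cccc(OCc2ccccc2)c1)c1ccc(Br)cc1`: 5400 nM
Compound 3 `O=C(/C=C/c1cccc(OCc2ccccc2)c1)c1cccc(Br)c1`: 7100 nM

In an ADME assay on HEK293 cells (Homo sapiens) for cytotoxicity, read by MTT assay, with a stated time of 68 h (on this read-out higher numbers stand for weaker inhibition and lower numbers for stronger inhibition), compound 1 gives the lowest number of the three, 2200 nM. Compound 2 stands a 2.5-fold higher number from compound 1 to compound 2 (0.39 log units; beyond the scatter) and compound 3 stands a 3.2-fold higher number from compound 1 to compound 3 (0.51 log units; beyond the scatter); between compound 2 and compound 3 the step is a 1.3-fold higher number from compound 2 to compound 3 (0.12 log units; within the scatter). So on this small set, the 2-bromophenyl of compound 1 goes with the lowest number, and moving the bromine elsewhere on the ring raises it by a modest amount.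

Compound 4 `O=C(/C=C/c1cccc(OCc2ccccc2)c1)c1ccc(O)cc1` has not yet been measured in this assay. It differs from compound 1 as follows: 4-hydroxyphenyl in place of 2-bromophenyl on a carbonyl carbon. Within the data shown here, only the steps from compound 1 to compound 2 and from compound 1 to compound 3 bear on this change, and only in part: they show what happens when the 2-bromophenyl is given up, but nothing measured here shows what a hydroxyl on that ring does. A modest rise in the number, of the size seen in those two steps, therefore seems the likeliest outcome, with wide uncertainty on either side.

For compound 4 an estimate of 6000 nM is expected, within a range of 2500 nM to 15000 nM, corresponding to an expected step of a 2.7-fold higher number from compound 1 to compound 4 (0.44 log units; beyond the scatter).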

Compound 4, half-maximal inhibitory concentration: 5400 nM
Beside the measured number, compound 4's estimate is 1.1-fold (0.05 log units) above it, within the range that was stated.
By their numbers in this assay, from the lowest: compound 1; then compounds 2, 4 and 3 (each within the scatter of the next).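

Swapping bromo for hydroxy on an aromatic carbon gives no change at the digits printed from compound 2 to compound 4 (within the scatter) in this assay, so this read-out does not separate the 4-hydroxyphenyl from the 4-bromophenyl, even though the 4-hydroxyphenyl carries 1 hydrogen-bond donor and 1 hydrogen-bond acceptor. The 4-hydroxyphenyl also cannot be told apart from the 3-bromophenyl, at a 1.3-fold lower number from compound 3 to compound 4 (0.12 log units; within the scatter), whereas a 2.5-fold higher number from compound 1 to compound 4 (0.39 log units; beyond the scatter) lies beyond the scatter, which extends what the bromine isomers showed: among these four compounds only the 2-bromophenyl stands apart, with the lowest number, and the other three aryl groups on the carbonyl carbon form one group, with no compound here going against this. No separate measurement bears on why this is so.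

The compounds shown leave open whether the lower number of compound 1 belongs to the bromine or to its place on the ring, a question that a 2-hydroxyphenyl or a 2-chlorophenyl would address. They also leave open whether the match of bromo and hydroxy extends to other groups on the same ring, such as an amine or a carboxylic acid.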